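The source may report more compounds than this note shows. Statements on the series, on what has been measured and on what is new or still open speak of the compounds shown alone.

For the measured compounds named here, in an ADME assay on MT4 cells (Homo sapiens) for cytotoxicity, read by XTT assay, with a stated time of 3 days (a lower number here means that less compound is tolerated, a higher number that more compound is tolerated), compound 3 `CCOCn1c(Cc2ccccc2)c(N(C)C)c(=O)[nH]c1=O` gives 166000 nM, the highest of the three numbers measured so far. Compound 1 `O=c1[nH]c(=O)n(COCc2ccccc2)c(Cc2ccccc2)c1I` gives 74800 nM, and compound 2 `O=c1[nH]c(=O)n(COCc2ccccc2)c(Cc2ccccc2)c1Br` gives 67400 nM; both lie lower than compound 3 by more than the scatter. Compound 4 `CN(C)c1c(Cc2ccccc2)n(COCc2ccccc2)c(=O)[nH]c1=O` differs from compound 3 by phenyl in place of methyl on a saturated chain carbon bound to an oxygen on a saturated carbon, turning ethoxymethyl into (benzyloxy)methyl. Going by the values given here, no measured step covers this change: the only one, a 1.1-fold lower number from compound 1 to compound 2 (0.05 log units; within the scatter), is bromo in place of iodo and stays within the scatter. Compound 2 does carry (benzyloxy)methyl, at 67400 nM, though it also differs from compound 3 elsewhere, so a moderate downward move is expected. The estimated change is a 2.0-fold lower number from compound 3 to compound 4 (0.29 log units; within the scatter). For compound 4 the expected value is 85000 nM, with an estimated range from 40000 nM to 170000 nM.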

Compound 4, half-maximal cytotoxic concentration: 91800 nM
For compound 4 the middle estimate is 1.1-fold (0.03 log units) below the measured one; the measured number falls inside the stated range.
By their numbers in this assay, from the lowest: compounds 2, 1, 4 and 3 (each within the scatter of the next, the first and the last beyond it).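

In this assay, phenyl in place of methyl on a saturated chain carbon bound to an oxygen on a saturated carbon gives a 1.8-fold lower number from compound 3 to compound 4 (0.26 log units; within the scatter) and so, turning ethoxymethyl into (benzyloxy)methyl, leaves the number within the scatter. With (benzyloxy)methyl held, dimethylamino in place of bromo gives a 1.4-fold higher number from compound 2 to compound 4 (0.13 log units; within the scatter) and dimethylamino in place of iodo gives a 1.2-fold higher number from compound 1 to compound 4 (0.09 log units; within the scatter) and so does not set dimethylamino apart from either halogen on that aromatic carbon. Nothing measured here explains these results. On these data alone, it remains open whether a carboxylic acid or an amine on the chain in place of phenyl, or morpholine in place of dimethylamino, would move the number beyond the scatter.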